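Methoxy for Chloro: Expected Tolerability of Compound 4

The compounds below may be only part of what the source reports. "The series", "measured", "known", "first", "only" and "open" are said of these compounds alone.

Compound 1 `Cc1nc(-c2cccnc2)sc1-c1nnc(Cc2ccccc2)o1` gives > 100 ug/mL in an ADME assay on THP-1 cells (Homo sapiens) for cytotoxicity, read by MTT assay (a higher number here means that more compound is tolerated, a lower number that less compound is tolerated), a limit of the assay.
Compound 2 `Cc1nc(-c2cccnc2)sc1-c1nnc(-c2ccc(Br)cc2)o1` gives > 100 ug/mL, also a limit.
Compound 3 `Cc1nc(-c2cccnc2)sc1-c1nnc(-c2ccccc2Cl)o1` gives > 100 ug/mL, again a limit.

Compound 3 therefore stands only at a limit, as do the two other values, all three sitting at the limit of > 100 ug/mL in this assay, at which 3 of the 3 values shown sit. The steps a step that the two limits leave unreadable from compound 1 to compound 2, a step that the two limits leave unreadable from compound 1 to compound 3 and a step that the two limits leave unreadable from compound 2 to compound 3 cannot be sized for that reason. Compound 4 `COc1ccccc1-c1nnc(-c2sc(-c3cccnc3)nc2C)o1` differs from compound 3 by methoxy in place of chloro on an aromatic carbon. Going by the values given here, no measured step touches a methoxy, so they bear on this change only by showing that every compound so far reached the limit. Compound 4 is expected to give 100 ug/mL (range 50 ug/mL to 200 ug/mL), with an estimated step of a number no higher from compound 3 to compound 4 (the limit leaves the size open) of no size beyond the scatter, most likely reported as a limit once more.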

Compound 4, half-maximal cytotoxic concentration: > 100 ug/mL
Compound 4: a limit, no number; the forecaster's own chance of this, stated with the estimate: 85%; the middle value sits exactly at the limit.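

The steps from compound 1, compound 2 and compound 3 to compound 4 cannot be read, since all four compounds stop at the same limit: the limit of > 100 ug/mL in this assay, at which 4 of the 4 values shown sit.

Left open is the concentration at which any of the four becomes cytotoxic in this assay, and so whether methoxy and chloro differ there at all.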